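Benzyl in Place of Butoxy: What to Expect for Compound 4

The source may report more compounds than this note shows. Statements on the series, on what has been measured and on what is new or still open speak of the compounds shown alone.

Compound 1, `COc1ccc(NC(=O)Nc2n[nH]c3ccccc23)cc1` — in a functional assay on Malme-3M cells (Homo sapiens) for inhibition, read by sulforhodamine B assay, with a stated time of 48 h (on this read-out lower numbers stand for stronger inhibition of growth and higher numbers for weaker inhibition of growth), compound 1 gives > 100000 nM
Compound 2, `CCCCOc1ccc(NC(=O)n2nc(N)c3ccccc32)cc1` — in this assay compound 2 gives 14700 nM
Compound 3, `Nc1nn(C(=O)Nc2c(F)cccc2F)c2ccccc12` — in this assay compound 3 gives < 100000 nM

Of the compounds shown here, three have so far been tested in this assay. Compound 2 is the only one of them for which a number exists; the other two results are limits of the assay. The result for compound 1 is a limit of the assay and not a number. The result for compound 3 is likewise a limit of the assay and not a number. Compound 2 therefore stands alone as the single measured point from which any expectation must start.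

Compound 4, `Nc1nn(C(=O)Nc2ccc(Cc3ccccc3)cc2)c2ccccc12`, shares the core of compound 2 and differs from it in one place: benzyl in place of butoxy on an aromatic carbon.

For the measured compounds named here, no step between two measured compounds exists, so there is nothing to read a direction from. The expected step from compound 2 to compound 4 is a 1.2-fold lower number from compound 2 to compound 4 (0.09 log units; within the scatter), a change estimated to lie within the usual scatter rather than beyond it. Compound 4 is accordingly expected to give about 12000 nM in this assay, with an estimated range from 4000 nM to 40000 nM.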

Compound 4, concentration for 50% growth inhibition: 19200 nM
Estimate against measurement, compound 4: 1.6-fold (0.20 log units) below, and the stated range covers the measured number.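

In this assay the series now has its first readable step, which is a 1.3-fold higher number from compound 2 to compound 4 (0.12 log units; within the scatter) and which lies within the usual scatter. At this place, on an aromatic carbon para to a large group, butoxy and benzyl therefore cannot be told apart on this read-out, even though butoxy takes away a chain with no ring and a hydrogen-bond acceptor, while benzyl brings a six-membered aromatic ring of carbon only. The values shown tie neither the ring nor the loss of the oxygen to any effect on growth inhibition, and nothing measured here explains why the two groups read alike.

For the compounds shown here, what a group of another kind would do at the same place stays open, whether a short methyl, an amine, a carboxylic acid or a longer chain than butoxy, as the step covers only this one pair of groups. Going by these compounds alone, compound 1 and compound 3 differ from compound 2 and compound 4 in more than one place, so they add no further step from which the role of this position could be read.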